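Swapping a nitrile for a primary amide on a weak inhibitor

The source may hold more compounds than are shown below. What is called first, only, known or untested is meant among the compounds shown, and "the series" means these compounds.

Measured so far:
compound 1, `NC(=O)c1cccc(-c2cnc(C(=O)CCCCCCc3ccccc3)o2)c1`, 6 nM
compound 2, `CN(C)C(=O)c1cnc(C(=O)CCCCCCc2ccccc2)o1`, 2 nM
compound 3, `N#Cc1cnc(C(O)CCCCCCc2ccccc2)o1`, 4200 nM

In an assay (Rattus norvegicus) for inhibition of Fatty-acid amide hydrolase 1 (Homo sapiens) (a higher number here means a weaker inhibitor, a lower number a stronger inhibitor), compound 3 gives 4200 nM, the highest of the three numbers and therefore the weakest inhibitor here; compound 1 and compound 2 sit far lower, and both carry a carbonyl in the side chain where compound 3 carries a hydroxyl. Compound 4, `NC(=O)c1cnc(C(O)CCCCCCc2ccccc2)o1`, keeps the core and chain of compound 3 and differs in one place: carbamoyl in place of cyano on an aromatic carbon.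

Among the measured compounds shown here, only one measured step is available, a 3.0-fold lower number from compound 1 to compound 2 (0.48 log units; beyond the scatter), and it exchanges one carbamoyl-bearing group for another on compounds that already differ from compound 3 in the side chain. For the measured compounds named here, it does not touch a cyano group, so no measured step bears directly on the change from compound 3 to compound 4. Compound 1 does show that a carbamoyl on the core region is compatible with strong inhibition, but compound 3 shows that the hydroxyl-bearing chain is weak regardless. The expected step is a 1.4-fold higher number from compound 3 to compound 4 (0.15 log units; within the scatter), with no direction beyond the scatter. For compound 4 the estimate in this assay is 6000 nM, expected between 1500 nM and 25000 nM.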

Compound 4, inhibition constant: 25000 nM
Compound 4: middle estimate off by 4.2-fold (0.62 log units), on the low side; measured number inside the range.
By their numbers in this assay, from the lowest: compound 2; then compound 1; then compound 3; then compound 4.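

On the aromatic carbon next to the ring oxygen, carbamoyl in place of cyano gives a 6.0-fold higher number from compound 3 to compound 4 (0.77 log units; beyond the scatter) in this assay, so this position responds to the group it carries even when the side chain holds a hydroxyl. Among the compounds shown here, this is the first measured step that starts from the cyano group, and it runs towards a weaker inhibitor; the only earlier step, between two compounds with a carbonyl in the side chain, involved no cyano group. The entering carbamoyl carries a hydrogen-bond donor that cyano lacks, but a single step cannot tie the weaker inhibition to that difference or to any other.

Nothing measured here explains why the number rises at this position. Going by these compounds, it remains open whether the same swap would shift the number as far with a carbonyl in the side chain in place of the hydroxyl, and how a carboxylic acid or an amine on this ring carbon would compare with cyano and carbamoyl.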